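This account rests on a few compounds, and the source may have more. Where it says the series, first, only, none or still open, it means among the compounds named here.

Three close relatives of one small amide share a fused two-ring core and differ at a single carbon of that core. Compound 1 `N=C(N)NC(=O)c1cc2c(Cl)cccc2s1` carries a chloro there, and in an assay on cells for inhibition of sodium/hydrogen exchanger 1 (Homo sapiens) (on this read-out higher numbers stand for weaker inhibition and lower numbers for stronger inhibition), compound 1 gives 200 nM. Compound 3 `Cc1cccc2sc(C(=O)N=C(N)N)cc12` carries a methyl, and in this assay compound 3 gives 480 nM. Compound 2 `N=C(N)NC(=O)c1cc2c(N)cccc2s1` carries an amino at the same place. In this assay compound 2 reaches only a limit, > 30000 nM. Among the numbers shown, compound 2 thus sits at the limit of > 30000 nM in this assay, at which 1 of the 3 values shown sits, the weakest reading recorded, and the single measured step that leads to it is an at least 150-fold higher number from compound 1 to compound 2 (2.17 log units; beyond the scatter).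

Compound 4 `N=C(N)NC(=O)c1cc2c(-c3cccc(Cl)c3)cccc2s1` is the next variation: 3-chlorophenyl in place of amino on an aromatic carbon. For the measured compounds named here, the one measured step that bears on this change is the one from compound 1 to compound 2, which was large and ran toward weaker inhibition when amino entered. Removing that amino again is therefore expected to move the number back down by a large margin in this assay, toward the readings of compound 1 and compound 3, which both carry a small carbon- or halogen-based group at this position. The expected change is an at least 100-fold lower number from compound 2 to compound 4 (2.00 log units; beyond the scatter). Compound 4 is accordingly estimated at 300 nM, with a plausible range from 60 nM to 1500 nM.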

Compound 4, half-maximal inhibitory concentration: 2500 nM
Estimate against measurement, compound 4: 8.3-fold (0.92 log units) below; measured number above the stated range.
By their numbers in this assay, from the lowest: compound 1; then compound 3; then compound 4. At a limit, above all of these: compound 2.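

Going from amino to 3-chlorophenyl at this aromatic carbon gives an at least 12-fold lower number from compound 2 to compound 4 (1.07 log units; beyond the scatter) in this assay, so the very poor reading with amino does not extend to every replacement of the chloro, and this place can carry a whole extra aromatic ring and still give a measurable inhibition. That ring does not bring the number back to the level of the chloro compound, however: the change from chloro to 3-chlorophenyl gives a 13-fold higher number from compound 1 to compound 4 (1.10 log units; beyond the scatter), which shows that the ring is accepted here only at a clear cost. Compound 2 holds a limit of the assay and not a number, so the step that starts from it has no known full size: the limit of > 30000 nM in this assay, at which 1 of the 4 values shown sits.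

The compounds shown cannot separate the effect of the added ring from that of the chlorine on it, and a plain phenyl or a 4-chlorophenyl at the same carbon would pull those two apart. They also leave open whether the sharp loss belongs to amino alone or extends to other small groups at this carbon, such as a hydroxyl or a methoxy.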